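The compounds below may be only part of what the source reports. "The series", "measured", "known", "first", "only" and "open" are said of these compounds alone.

Compound 2 `COc1cccc(NC(=O)N[C@H](C)c2ccccc2)c1` carries a methoxy group on the aromatic ring of the shared core. In an ADME assay on the whole organism with Oryza sativa as the target, tested at 0.1 uM (on this read-out lower numbers stand for a stronger effect and higher numbers for a weaker effect at the one concentration tested), compound 2 gives 104%. Among the compounds with values here, its only companion so far is compound 1 `CCc1cccc(NC(=O)N[C@H](C)c2ccccc2)c1`, which in this assay gives 97%; the single step, a number 7 percentage points higher from compound 1 to compound 2 (within the scatter), lies within the scatter, so the two numbers cannot be told apart, and compound 2 stands simply alongside compound 1 rather than above or below it.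

The next compound, compound 3 `C[C@@H](NC(=O)Nc1cccc(I)c1)c1ccccc1`, is reached by a change at the same aromatic carbon: iodo in place of methoxy on an aromatic carbon. Within the data shown here, no measured step shows an iodo group entering; the only step seen, from compound 1 to compound 2, replaces a different group at that position and was itself within the scatter. That step is therefore only a weak guide, and nothing in the data points to a shift in either direction. The expectation is a step of a number 6 percentage points lower from compound 2 to compound 3 (within the scatter) in this assay, nothing beyond the scatter. Compound 3 is accordingly estimated at 98%, with a range from 85% to 110%.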

Compound 3, a percentage reported as activity, at one concentration (the size of the read-out at that concentration, not a potency): 81%
Beside the measured number, compound 3's estimate is 17 percentage points above it; the whole stated range lies above it.
By their numbers in this assay, from the lowest: compound 3; then compounds 1 and 2 (each within the scatter of the next).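

Iodo is the first group at this aromatic carbon, meta to a large group, to move the read-out beyond the scatter: in this assay it gives a number 23 percentage points lower from compound 2 to compound 3 (beyond the scatter), and set against ethyl it gives a number 16 percentage points lower from compound 1 to compound 3 (beyond the scatter). Ethyl and methoxy could not be told apart here, so the position does respond to what it carries, and the lower number means a stronger effect at the one concentration tested, whichever of the two groups iodo replaces. Nothing available indicates why iodo differs from ethyl and methoxy.

The three compounds cannot show whether this shift is particular to iodo or would also appear with bromo or chloro, nor what an amine or a carboxylic acid would do on the same carbon. They also leave open whether iodo would give a similar step if another part of the shared core were changed, since only this one position varies among them.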